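One fluoro fewer: from compound 1 to compound 3

A few compounds are considered here, and "the series" means these few. Any claim that something is new, unique, unknown or untested is made for them only; others in the source may bear on it.

Measured so far:
- compound 1 (`O=C1CN(S(=O)(=O)c2c(F)cccc2F)c2cc(Cl)ccc2N1`) : 180000 nM
- compound 2 (`O=c1[nH]c2ccc(Cl)cc2n1S(=O)(=O)c1ccccc1F`) : > 382000 nM (a limit of the assay, not a number)

Among the measured compounds shown here, in an ADME assay on MT4 cells (Homo sapiens) for cytotoxicity, with a stated time of 5 days (on this read-out lower numbers stand for higher toxicity in this test and higher numbers for lower toxicity in this test), compound 1 gives the only actual number of the series, 180000 nM. The entry for compound 2 is a limit and gives no number.

Compound 3 (`O=C1CN(S(=O)(=O)c2ccccc2F)c2cc(Cl)ccc2N1`) has not yet been measured. Its structure departs from compound 1 in one place: hydrogen in place of fluoro on an aromatic carbon. This is hydrogen in place of fluoro on an aromatic carbon, ortho to a large group and meta to a fluoro group.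

For the measured compounds named here, no measured step between compounds differing in one place is available, so the expectation rests on compound 1 at 180000 nM alone. No change beyond the usual scatter is expected in this assay, in either direction. The estimated 1.1-fold higher number from compound 1 to compound 3 (0.05 log units; within the scatter) stays within that scatter. For compound 3 the expected value is 200000 nM, with an estimated range of 90000 nM to 400000 nM.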

Compound 3, half-maximal cytotoxic concentration: 197000 nM
Compound 3: the middle estimate sits 1.0-fold (0.01 log units) above what was measured; measured number inside the range.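

In this assay, hydrogen in place of fluoro on an aromatic carbon, ortho to a large group and meta to a fluoro group, gives a 1.1-fold higher number from compound 1 to compound 3 (0.04 log units; within the scatter). Among the compounds shown here, this is the first single-place step, and at this position the read-out does not separate the fluoro from the hydrogen. Compound 2 could not show this, as its entry is a limit and not a number: the limit of > 382000 nM in this assay, at which 1 of the 3 values shown sits.

From the compounds shown here alone, whether a larger group at this position, such as methoxy, trifluoromethyl or an amine, would move the read-out beyond the scatter remains open. For the compounds shown here, compound 1 and compound 3 also share the chloro on the core, so a replacement there, for instance by a nitrile, has no step to go on.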